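Phenyl for naphthyl amides on two chromone cores

The compounds below may be only part of what the source reports. "The series", "measured", "known", "first", "only" and "open" are said of these compounds alone.

Measured compounds:
Compound 1, `O=C(COc1c(-c2ccccc2)oc2ccccc2c1=O)Nc1ccc2ccccc2c1`: > 10000 nM
Compound 2, `O=C(COc1ccc2c(=O)cc(-c3ccccc3)oc2c1)Nc1ccc2ccccc2c1`: > 10000 nM
Compound 3, `O=C(COc1c(-c2ccccc2)oc2ccccc2c1=O)Nc1ccccc1`: 6720 nM

In a functional assay on MT2 cells (Homo sapiens) for antiproliferative activity, read by MTT assay, with a stated time of 72 h (a lower number here means a stronger inhibitor of growth, a higher number a weaker inhibitor of growth), compound 1 reaches only a limit, > 10000 nM. Compound 2 is built on a core that differs from that of compound 1 in a way not broken down here; compound 2 likewise gives only a limit, > 10000 nM. Compound 3 gives a number, 6720 nM. The change phenyl in place of naphthalen-2-yl on an amide-type nitrogen produced an at least 1.4-fold lower number from compound 1 to compound 3 (0.17 log units; that floor lies within the scatter); the step is known only as a floor because of the limit of > 10000 nM in this assay, at which 2 of the 3 values shown sit. Compound 4, `O=C(COc1ccc2c(=O)cc(-c3ccccc3)oc2c1)Nc1ccccc1`, arises from compound 2 by the same change, (phenyl in place of naphthalen-2-yl on an amide-type nitrogen). Since compound 2 sits at a limit, the outcome for compound 4 is expected to resemble the earlier step, an at least 1.2-fold lower number from compound 2 to compound 4 (0.09 log units; that floor lies within the scatter), resting on an at least 1.4-fold lower number from compound 1 to compound 3 (0.17 log units; that floor lies within the scatter). Compound 4 is therefore estimated at 8000 nM, between 3000 nM and 20000 nM.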

Compound 4, concentration for 50% growth inhibition: > 10000 nM
Compound 4: no number, only a limit; the forecaster's own chance of this, stated with the estimate: 50%; middle value at least 1.2-fold (0.09 log units) away from the limit.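

Compound 4 gives > 10000 nM in this assay, which is a limit. The step from compound 2 to compound 4 cannot be read, because both compounds stand at a limit: the limit of > 10000 nM in this assay, at which 3 of the 4 values shown sit.

The compounds shown leave open how far compound 2 and compound 4 lie beyond that limit.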